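A few compounds are considered here, and "the series" means these few. Any claim that something is new, unique, unknown or untested is made for them only; others in the source may bear on it.

Four compounds share one core. Compound 1 `Brc1ccc2[nH]c(-c3cncn3Cc3ccccc3)cc2c1` gives 13600 nM in an assay on isolated protein for inhibition of Indoleamine 2,3-dioxygenase 1 (Homo sapiens), with a stated time of 1 h; on this read-out higher numbers stand for weaker inhibition and lower numbers for stronger inhibition. Compound 2 `c1ccc(Cn2cncc2-c2cc3ccccc3[nH]2)cc1` gives 34800 nM in this assay, and compound 3 `Brc1ccc2[nH]c(-c3cncn3Cc3ccc(-c4ccccc4)cc3)cc2c1` gives 34200 nM. Compound 3 thus stands second highest of the three, within the scatter of compound 2 and a weaker inhibitor than compound 1. Compound 4 `Cc1ccc(Cn2cncc2-c2cc3cc(Br)ccc3[nH]2)cc1` differs from compound 3 by methyl in place of phenyl on an aromatic carbon. Within the data shown here, one measured step bears on this change: a 2.5-fold higher number from compound 1 to compound 3 (0.40 log units; beyond the scatter), where the phenyl entered. Taking most of that group away again is expected to undo part of that step, so compound 4 is expected to fall between compound 1 and compound 3. The expected step is a 1.7-fold lower number from compound 3 to compound 4 (0.23 log units; within the scatter). The estimate for compound 4 is 20000 nM, with a range from 9000 nM to 45000 nM.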

Compound 4, half-maximal inhibitory concentration: 21600 nM
Estimate against measurement, compound 4: 1.1-fold (0.03 log units) below; the range from low to high includes it.
By their numbers in this assay, from the lowest: compounds 1, 4, 3 and 2 (each within the scatter of the next, the first and the last beyond it).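

Methyl on this aromatic carbon cannot be told apart from either phenyl or hydrogen in this assay: the steps are a 1.6-fold lower number from compound 3 to compound 4 (0.20 log units; within the scatter) and a 1.6-fold higher number from compound 1 to compound 4 (0.20 log units; within the scatter). Only the two ends of this short series, hydrogen in compound 1 and phenyl in compound 3, stand beyond the scatter of each other, so methyl does not show how much of a group this place tolerates. Nothing measured here explains these numbers. As far as these compounds go, whether an amine, a carboxylic acid or a methoxy group at this place would differ clearly from hydrogen stays open.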